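Thioether chain variation on a shared pyridopyrimidine-type core

A few compounds are considered here, and "the series" means these few. Any claim that something is new, unique, unknown or untested is made for them only; others in the source may bear on it.

Compound 1 `C#CCSc1nc(Nc2cccc(Cl)c2)c2ccncc2n1` — 1090 nM
Compound 2 `C#CCSc1nc(Nc2cc(OC)c(OC)c(OC)c2)c2ccncc2n1` — 14200 nM
Compound 3 `CCCSc1nc(Nc2cccc(OC)c2)c2ccncc2n1` — 17300 nM

In a functional assay on HepG2 cells (Homo sapiens) for inhibition, read by MTT assay, with a stated time of 72 h (a higher number here means a weaker inhibitor, a lower number a stronger inhibitor), compound 3 gives 17300 nM, the highest of the three numbers. Compound 2, with 14200 nM, lies within the scatter of it. Compound 1, with 1090 nM, lies beyond the scatter, with a markedly lower number.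

Compound 4 `COc1cccc(Nc2nc(SCC3CC3)nc3cnccc23)c1` differs from compound 3 only by cyclopropyl in place of ethyl on a saturated chain carbon bound to a sulfur. For the measured compounds named here, no pair of measured compounds shows this kind of change, so its size is unknown here. The step from compound 3 to compound 4 is expected as a 1.2-fold lower number from compound 3 to compound 4 (0.06 log units; within the scatter), not beyond the scatter in either direction. Compound 4 is therefore expected to give 15000 nM, with a range from 5000 nM to 45000 nM.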

Compound 4, half-maximal inhibitory concentration: 24900 nM
Estimate against measurement, compound 4: 1.7-fold (0.22 log units) below, within the range that was stated.
By their numbers in this assay, from the lowest: compound 1; then compounds 2, 3 and 4 (each within the scatter of the next).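

In this assay, cyclopropyl in place of ethyl on a saturated chain carbon bound to a sulfur gives a 1.4-fold higher number from compound 3 to compound 4 (0.16 log units; within the scatter) and stays within the scatter, so propyl to cyclopropylmethyl leaves no readable shift at this position. This single pair is the only size available for this kind of change in the series. Nothing measured here bears on the reason for this result.

Still open, going by these compounds, is whether an amine or a carboxylic acid on the thioether chain, or a longer chain, would move the number beyond the scatter.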